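Adding trifluoromethyl to a chlorophenyl amide

The compounds below may be only part of what the source reports. "The series", "measured", "known", "first", "only" and "open" are said of these compounds alone.

compound 1 `CN(C)C(=O)c1cc2cnc(Nc3ccc(NC(=O)C4(C(=O)Nc5cccc(O)c5)CC4)cc3)nc2n1C1CCCC1` gives 94.9%
compound 2 `CN(C)C(=O)c1cc2cnc(Nc3ccc(NC(=O)C4(C(=O)Nc5cccc(Cl)c5)CC4)cc3)nc2n1C1CCCC1` gives 101%

In a functional assay on NCI-H460 cells (Homo sapiens) for inhibition, read by CCK-8 assay, with a stated time of 72 h, tested at 10 uM (a lower number here means less inhibition of growth, a higher number more inhibition of growth at the concentration tested), compound 2 stands at 101% and lies within the scatter of compound 1. Compound 3 `CN(C)C(=O)c1cc2cnc(Nc3ccc(NC(=O)C4(C(=O)Nc5ccc(Cl)c(C(F)(F)F)c5)CC4)cc3)nc2n1C1CCCC1` differs from compound 2 by 4-chloro-3-(trifluoromethyl)phenyl in place of 3-chlorophenyl on an amide-type nitrogen and keeps the shared core. Among the measured compounds shown here, one measured step bears on this group (a number 6.1 percentage points higher from compound 1 to compound 2 (within the scatter)), and it swapped hydroxy for chloro on an aromatic carbon. For the measured compounds named here, no measured compound carries trifluoromethyl, so that part of the change is untested. No step beyond the scatter is therefore expected in this assay for this change. The expected step stays within the scatter (a number 4 percentage points lower from compound 2 to compound 3 (within the scatter)). The estimate for compound 3 is 97% (expected range 86% to 106%).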

Compound 3, percent growth inhibition at one concentration: 91.9%
The estimate for compound 3 lay 5.1 percentage points above the measured number; the measured number falls inside the stated range.
By their numbers in this assay, from the lowest: compounds 3, 1 and 2 (each within the scatter of the next).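

Trifluoromethyl now has a reading at this position in this assay: the change to 4-chloro-3-(trifluoromethyl)phenyl on the amide-type nitrogen gives a number 9.1 percentage points lower from compound 2 to compound 3 (within the scatter) and, set against the hydroxy compound, a number 3 percentage points lower from compound 1 to compound 3 (within the scatter). The three aryl groups therefore cannot be told apart at this single concentration, and adding trifluoromethyl to the chlorophenyl amide brings no step beyond the scatter. Nothing available explains this result. From the compounds shown here alone, whether these groups would separate at lower concentrations stays open, as does how an amine or a carboxylic acid on this ring would read.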